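This account rests on a few compounds, and the source may have more. Where it says the series, first, only, none or still open, it means among the compounds named here.

Measured compounds in a functional assay on MCF7 cells (Homo sapiens) for antiproliferative activity, read by sulforhodamine B assay, with a stated time of 72 h; a lower number here means a stronger inhibitor, a higher number a weaker inhibitor:
compound 1 `CCCCS(=O)(=O)Nc1cc(-c2ccc3ncnc(NCCN(C)C)c3c2)cnc1OC` — 3240 nM
compound 2 `COc1ncc(-c2ccc3ncnc(NCCN(C)C)c3c2)cc1NS(C)(=O)=O` — 14700 nM

For the measured compounds named here, compound 1 gives the lowest of the two numbers in this assay; its only neighbour is compound 2, reached by a 4.5-fold higher number from compound 1 to compound 2 (0.66 log units; beyond the scatter) through hydrogen in place of propyl on a saturated chain carbon bound to a sulfonyl sulfur. Going by the values given here, that is the one measured step in the set, and it concerns the sulfonamide chain, not the amine-bearing side chain on the shared core.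

Compound 3 `CCCCS(=O)(=O)Nc1cc(-c2ccc3ncnc(NCCCN(C)C)c3c2)cnc1OC` differs from compound 1 by (dimethylamino)methyl in place of dimethylamino on a saturated chain carbon, two bonds along the chain from a nitrogen on an aromatic ring. Among the compounds with values here, no measured step touches this part of the structure, so nothing in the set speaks for or against a shift in this assay; the step from compound 1 to compound 2 gives no guidance here. The change is small and keeps the same donor and acceptor count, so the expectation is a step within the scatter: a 1.0-fold higher number from compound 1 to compound 3 (0.01 log units; within the scatter) is the estimated move, with no clear direction. Compound 3 is therefore expected near compound 1, at 3300 nM with a range of 1200 nM to 9500 nM.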

Compound 3, half-maximal inhibitory concentration: 4730 nM
Compound 3: the middle estimate sits 1.4-fold (0.16 log units) below what was measured, within the range that was stated.
By their numbers in this assay, from the lowest: compounds 1 and 3 (each within the scatter of the next); then compound 2.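

In this assay, the amine-bearing side chain now has a measured step of its own: going from (2-(dimethylamino)ethyl)amino to (3-(dimethylamino)propyl)amino gives a 1.5-fold higher number from compound 1 to compound 3 (0.16 log units; within the scatter), so the number stays within the scatter. With the propyl on the sulfonyl-bound chain carbon held fixed, this position therefore accepts (dimethylamino)methyl in place of dimethylamino without a readable shift, whereas the sulfonamide-chain change gives a 4.5-fold higher number from compound 1 to compound 2 (0.66 log units; beyond the scatter), which is beyond the scatter. No measured data are available to explain the outcome of this side-chain change.

The compounds shown leave open whether the same side-chain change would stay within the scatter on the methyl sulfonamide of compound 2, since that pair has no counterpart here. Also open, on these data alone, are a longer chain such as 4-(dimethylamino)butyl and other end groups such as a diethylamino group or a primary amine, which would show how far this position can be altered before the number in this assay moves beyond the scatter.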